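This account rests on a few compounds, and the source may have more. Where it says the series, first, only, none or still open, it means among the compounds named here.

Measured so far:
- compound 1 `COc1ncc(N2CCc3ncnc(O[C@H]4CCN(C(=O)C5CCOCC5)C4)c3C2)cc1C(F)(F)F`: 270000 nM
- compound 2 `COc1ncc(N2CCc3ncnc(O[C@H]4CCN(C(=O)C5CCOCC5)C4)c3C2)cc1C`: > 1000000 nM, a limit

For the measured compounds named here, in a physicochemical assay for solubility, read by LC-MS, measured as thermodynamic solubility, at pH 6.8 (on this read-out lower numbers stand for lower solubility and higher numbers for higher solubility), compound 1 stands at 270000 nM, the only actual number in this short series. Compound 2 gives > 1000000 nM, which is a limit of the assay and not a number. Going by the values given here, the one measured step is an at least 3.7-fold higher number from compound 1 to compound 2 (0.56 log units; beyond the scatter), and its size is bounded by that limit (the limit of > 1000000 nM in this assay, at which 1 of the 2 values shown sits).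

Compound 3 `CCC(=O)N1CC[C@H](Oc2ncnc3c2CN(c2cnc(OC)c(C(F)(F)F)c2)CC3)C1` keeps the trifluoromethyl of compound 1 and differs at the amide: ethyl in place of oxan-4-yl on a carbonyl carbon. Among the compounds with values here, no measured step covers a change at this place. The methyl for trifluoromethyl step bears on it only indirectly, by showing that a single change in this series can move this assay beyond the scatter. It gives neither a size nor a direction here, so the expectation stays anchored on compound 1 at 270000 nM. The estimated step is a 1.1-fold lower number from compound 1 to compound 3 (0.03 log units; within the scatter), which is not expected to go beyond the scatter, in either direction. The estimate for compound 3 is 250000 nM, with an expected range from 90000 nM to 700000 nM.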

Compound 3, solubility: 80000 nM
The estimate for compound 3 lay 3.1-fold (0.49 log units) above the measured number; the measured number lies below the stated range.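

In this assay the place on the carbonyl carbon now has a measured step of its own, with ethyl in place of oxan-4-yl: a 3.4-fold lower number from compound 1 to compound 3 (0.53 log units; beyond the scatter). The aromatic carbon is therefore no longer the only place in the series where a single change moves the number beyond the scatter, and this step runs the opposite way to an at least 3.7-fold higher number from compound 1 to compound 2 (0.56 log units; beyond the scatter) on that carbon. Nothing measured here accounts for the step at the carbonyl carbon, which stands as an observation on this one pair of compounds.

Open, from the compounds shown here alone, is how the number moves with other groups on the same carbonyl carbon, such as a longer chain, a chain bearing an amine or one bearing a carboxylic acid, and whether ethyl in place of oxan-4-yl gives a step of similar size when methyl rather than trifluoromethyl sits on the aromatic carbon. Going by these compounds, compound 2 gives > 1000000 nM, which is a limit and not a number, so the true size of the step to it stays open: the limit of > 1000000 nM in this assay, at which 1 of the 3 values shown sits.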